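The source may report more compounds than this note shows. Statements on the series, on what has been measured and on what is new or still open speak of the compounds shown alone.

Measured in an assay on isolated protein for binding affinity to histone acetyltransferase KAT2B (Homo sapiens), read by isothermal titration calorimetry; on this read-out lower numbers stand for tighter binding and higher numbers for weaker binding:

- compound 1, `CN1C[C@H](Nc2nc3cc[nH]c3c(=O)n2C)C[C@H](c2cccc(Br)c2)C1`, gives 128 nM
- compound 2, `CCCCc1ccc([C@H]2C[C@@H](Nc3nc4cc[nH]c4c(=O)n3C)CN(C)C2)cc1`, gives 183 nM

Compound 2 stands at the higher of these two numbers, yet the gap to compound 1 is within the usual scatter of repeated measurements, so the two compounds read as alike in this assay.

Compound 3, `CN1C[C@H](Nc2nc3cc[nH]c3c(=O)n2C)C[C@H](c2ccc(OC(F)(F)F)cc2)C1`, is built from compound 2 by one change: trifluoromethoxy in place of butyl on an aromatic carbon. For the measured compounds named here, no pair of measured compounds shows what this change does, so there is no measured step to lean on. Going by the values given here, with only two compounds known, both close together, the expectation for compound 3 is a small step, if any, rather than one beyond the scatter, and it could go either way.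

Compound 3 is therefore estimated at 200 nM, with a range from 80 nM to 500 nM. The step this estimate implies is a 1.1-fold higher number from compound 2 to compound 3 (0.04 log units; within the scatter), expected to stay within the scatter.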

Compound 3, dissociation constant: 140 nM
Compound 3: middle estimate off by 1.4-fold (0.15 log units), on the high side; the measured number falls inside the stated range.
By their numbers in this assay, from the lowest: compounds 1, 3 and 2 (each within the scatter of the next).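

In this assay, putting trifluoromethoxy in place of butyl on the aromatic carbon, para to a large group, gives a 1.3-fold lower number from compound 2 to compound 3 (0.12 log units; within the scatter). For the compounds shown here, this is the only measured step at this position, and it shows that a carbon-only chain can be exchanged for a group of oxygen, fluorine and one carbon, with one hydrogen-bond acceptor where butyl has none, without the number leaving the scatter. Nothing at hand says why these two groups read alike.

As far as these compounds go, whether an amine, a carboxylic acid or a longer chain at this same place would also stay within the scatter of compound 2 remains open. Also open, from the compounds shown here alone, is whether plain hydrogen there would read the same, which would show whether a group at this position matters at all.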